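Isopropyl in place of hydroxy hydrogen on the amide core

The compounds below may be only part of what the source reports. "The series", "measured", "known", "first", "only" and "open" are said of these compounds alone.

The series shares a benzamide core bearing an oxygen substituent and a pyridyl partner. Compound 1 `NCCOc1cc(-c2cccnc2)ccc1C(N)=O` carries a 2-aminoethyl group on that oxygen, and in an assay on cells for inhibition of MAP kinase-interacting serine/threonine-protein kinase 1 (Homo sapiens), read by mobility shift assay, with stated times of 10 min and 60 min, in the presence of a further agent that is not named here (on this read-out higher numbers stand for weaker inhibition and lower numbers for stronger inhibition), compound 1 gives 820 nM. Compound 2 `NC(=O)c1ccc(-c2cccnc2)cc1O` keeps only a hydrogen there, and in this assay compound 2 gives 4300 nM, the highest of the three numbers recorded; its nearest neighbour is compound 1, while compound 3 `CC(C)Oc1cc(-c2cncc(-c3cnn(C4CCOC4)c3)c2)ccc1C(N)=O`, which carries an isopropyl group on the oxygen together with a larger partner ring, gives 120 nM in this assay and stands furthest away.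

Compound 4 `CC(C)Oc1cc(-c2cccnc2)ccc1C(N)=O` has not yet been measured. Relative to compound 2 the change is isopropyl in place of hydrogen on an oxygen on an aromatic ring. Within the data shown here, the one directly comparable step is a 5.2-fold higher number from compound 1 to compound 2 (0.72 log units; beyond the scatter), which shows that removing a group from this oxygen raised the number by a modest but real amount. Compound 3, though it differs in more than one place, also shows a far lower number with an isopropyl on the same oxygen. The expected step is therefore downward, a 7.2-fold lower number from compound 2 to compound 4 (0.86 log units; beyond the scatter), beyond the scatter. For compound 4 in this assay the estimate is 600 nM, ranging from 150 nM to 2500 nM.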

Compound 4, half-maximal inhibitory concentration: 880 nM
For compound 4 the middle estimate is 1.5-fold (0.17 log units) below the measured one, within the range that was stated.
By their numbers in this assay, from the lowest: compound 3; then compounds 1 and 4 (each within the scatter of the next); then compound 2.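

In this assay, the change from hydroxy to isopropoxy gives a 4.9-fold lower number from compound 2 to compound 4 (0.69 log units; beyond the scatter) and so shows directly, on an otherwise unchanged pair, that a group on this oxygen lowers the number even when it is a plain isopropyl carrying no nitrogen. The comparison between the two groups adds the more telling point: a 1.1-fold higher number from compound 1 to compound 4 (0.03 log units; within the scatter) leaves isopropyl and 2-aminoethyl indistinguishable on this read-out, so the amine of compound 1 is not required for a number at this level, and among these three compounds only the free hydroxy of compound 2 stands apart. No measurement is given here that would explain why these groups behave alike on this oxygen.

Among these compounds, what remains open is whether this level holds for other groups on the same oxygen, such as a methyl, a longer chain or a carboxylic acid, since only two groups have been compared with hydrogen here. From the compounds shown here alone, it is also open whether a 2-aminoethyl group would match isopropyl on the larger partner ring of compound 3.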